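The compounds below may be only part of what the source reports. "The series", "measured", "known", "first", "only" and "open" are said of these compounds alone.

Compound 1 `Cc1noc(-c2nc(C)c3c(c2N)C(=O)N(Cc2ccccc2F)C3=O)n1`, compound 2 `COc1ccccc1CN1C(=O)c2c(C)nc(-c3nc(C)no3)c(N)c2C1=O` and compound 3 `Cc1noc(-c2nc(C)c3c(c2N)C(=O)N(Cc2ccc(C(N)=O)cc2)C3=O)n1` share one core and were tested in a physicochemical assay for solubility, using the shake flask method, in simulated intestinal fluid, measured as kinetic solubility, with a stated time of 2 h, at 25 degrees C, at pH 6.5; on this read-out lower numbers stand for lower solubility and higher numbers for higher solubility. Compound 1 gives < 5000 nM, which is a limit and not a number. Compound 2 gives < 5000 nM, also a limit. Compound 3 gives < 5000 nM, again a limit. The whole set therefore stands at the limit of < 5000 nM in this assay, at which 3 of the 3 values shown sit, and compound 3 has no exact number of its own.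

Compound 4 `Cc1noc(-c2nc(C)c3c(c2N)C(=O)N(Cc2ccc(N(C)C)cc2)C3=O)n1` keeps the core of compound 3 and carries dimethylamino in place of carbamoyl on an aromatic carbon, para to a large group: dimethylamino in place of carbamoyl on an aromatic carbon. Among the measured compounds shown here, no measured step makes this same swap. The closest measured changes are a step that the two limits leave unreadable from compound 1 to compound 3 and a step that the two limits leave unreadable from compound 2 to compound 3, and both alter the same aromatic group. Neither has a size to carry over, so no direction can be drawn from them, and no step beyond the scatter is expected. The expected outcome, in estimated terms, is a step that the limit leaves unreadable from compound 3 to compound 4. Compound 4 is estimated at 3000 nM, with an expected range from 1000 nM to 6000 nM.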

Compound 4, solubility: 7400 nM
Compound 4: the middle estimate sits 2.5-fold (0.39 log units) below what was measured; measured number outside the range, above it.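

Compound 4 is the first compound here with an exact number in this assay, so this place on the aromatic ring, para to a large group, now has a real read-out and not only a limit: the limit of < 5000 nM in this assay, at which 3 of the 4 values shown sit.

Set against those limits, the new value gives an at least 1.4-fold higher number from compound 3 to compound 4 (0.17 log units; that floor lies within the scatter), an at least 1.4-fold higher number from compound 2 to compound 4 (0.17 log units; that floor lies within the scatter) and an at least 1.4-fold higher number from compound 1 to compound 4 (0.17 log units; that floor lies within the scatter). From the compounds shown here alone, each of these is only a floor, so the true size of the change to dimethylamino stays unknown, and the steps among compound 1, compound 2 and compound 3 cannot be read.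

Going by these compounds, what a primary amine, morpholine or a carboxylic acid would give at this same place remains open. With a single exact number, no trend across groups at this place can yet be drawn.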